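The source may hold more compounds than are shown below. What is called first, only, known or untested is meant among the compounds shown, and "the series" means these compounds.

Compound 1, `Nc1scc(CN2CCN(c3ccc([N+](=O)[O-])cc3)CC2)c1C(=O)c1ccc(Cl)cc1`: in a functional assay on CHO cells with adenosine receptor A1 (Homo sapiens) as the target, read by cAMP accumulation and immunoassay, with a stated time of 6 min, tested at 1 uM (a lower number here means a stronger effect, a higher number a weaker effect of the compound at the concentration tested), compound 1 gives -8.3%.
Compound 2, `Nc1scc(CN2CCN(c3cccc(C(F)(F)F)c3)CC2)c1C(=O)c1ccc(Cl)cc1`: in this assay compound 2 gives -72%.
Compound 3, `Nc1scc(CN2CCN(C3CCCCCC3)CC2)c1C(=O)c1ccc(Cl)cc1`: in this assay compound 3 gives 3.7%.

Compound 3 stands highest of the three in this assay, that is, it shows the weakest effect of the set. The two steps that reach it both go upward: a number 12 percentage points higher from compound 1 to compound 3 (beyond the scatter), and a number 75.7 percentage points higher from compound 2 to compound 3 (beyond the scatter). In both, a six-membered aromatic ring on the ring nitrogen is exchanged for cycloheptyl, and the number rises.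

Compound 4, `Nc1scc(CN2CCN(c3cccc(F)c3F)CC2)c1C(=O)c1ccc(Cl)cc1`, reverses that kind of exchange: 2,3-difluorophenyl in place of cycloheptyl on an amine nitrogen in a ring. The two measured steps bear on it directly, read backwards: putting an aromatic ring in place of cycloheptyl lowered the number by a modest amount for one ring and by a large amount for the other. A step downward in this assay is therefore expected for compound 4, of uncertain size because the two aromatic rings differed so much, as a number 75.7 percentage points higher from compound 2 to compound 3 (beyond the scatter) and a number 12 percentage points higher from compound 1 to compound 3 (beyond the scatter) show. The expected step is a number 38.7 percentage points lower from compound 3 to compound 4 (beyond the scatter). For compound 4 the estimate in this assay is -35%, with a range from -80% to 5%.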

Compound 4, a percentage reported as activity, at one concentration (the size of the read-out at that concentration, not a potency): -66%
The estimate for compound 4 lay 31 percentage points above the measured number; the measured number falls inside the stated range.
By their numbers in this assay, from the lowest: compounds 2 and 4 (each within the scatter of the next); then compound 1; then compound 3.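

The exchange of cycloheptyl for 2,3-difluorophenyl gives a number 69.7 percentage points lower from compound 3 to compound 4 (beyond the scatter) in this assay and so adds a second aromatic ring with a large downward step on this amine nitrogen. Against the 3-(trifluoromethyl)phenyl ring, the new ring gives a number 6 percentage points higher from compound 2 to compound 4 (within the scatter) and so the two rings cannot be told apart, which means a low number here does not depend on the trifluoromethyl group itself. The 4-nitrophenyl ring now stands out as the one aromatic ring that goes against this pattern, with a number 57.7 percentage points lower from compound 1 to compound 4 (beyond the scatter) as the gap to the new compound.

A plain phenyl ring, or one carrying a methoxy group or an amine, would show whether the low numbers need fluorine-bearing groups at all, and the compounds shown cannot separate the kind of group from where it sits on the ring. Nothing available explains why the 4-nitrophenyl ring differs from the other two aromatic rings.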